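The source may report more compounds than this note shows. Statements on the series, on what has been measured and on what is new or still open speak of the compounds shown alone.

Compound 1 `CC(C(=O)NCc1ccc(C(F)(F)F)cc1N1CCC(C(F)(F)F)CC1)c1ccc(NS(C)(=O)=O)c(F)c1` and compound 2 `C[C@H](C(=O)NCc1ccc(C(F)(F)F)cc1SC1CCCCC1)c1ccc(NS(C)(=O)=O)c(F)c1` share a core and differ only in the group sitting on the aromatic ring that carries the trifluoromethyl group. In an assay on CHO cells for antagonist activity at transient receptor potential cation channel subfamily V member 1 (Homo sapiens), read by FLIPR (a higher number here means a weaker inhibitor, a lower number a stronger inhibitor), compound 1 gives 0.4 nM, and compound 2 gives 0.3 nM; the two numbers lie within the scatter of each other, so the data do not separate them. Compound 3 `CC(C(=O)NCc1ccc(C(F)(F)F)cc1[N+](=O)[O-])c1ccc(NS(C)(=O)=O)c(F)c1` has not been measured. It arises from compound 1 by one change: nitro in place of 4-(trifluoromethyl)piperidin-1-yl on an aromatic carbon. A ring group leaves and a nitro group enters at the same place, a change far larger than anything shown between the two measured compounds, for which no step is recorded. The step of a 50-fold higher number from compound 1 to compound 3 (1.70 log units; beyond the scatter) is expected to be large and to go toward a weaker inhibitor. For compound 3 in this assay the estimate is 20 nM, with a range from 3 nM to 150 nM.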

Compound 3, inhibition constant: "not active" (no number reported)
No number was reported for compound 3; no gap can be computed for the estimate.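

Within the data shown here, compound 3 is reported as not active, with no number, so no step between compound 1 and compound 3 can be read. The compounds shown leave open how large the gap between these two compounds is. Nothing shown bears on the reason for this result.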